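Sulfonamide aniline in place of the ethynyl group of compound 3

A few compounds are considered here, and "the series" means these few. Any claim that something is new, unique, unknown or untested is made for them only; others in the source may bear on it.

Compound 1 `O=C(Nc1cccc(-c2nc(-c3ccc(NC(=O)c4cccnc4)cc3Cl)no2)c1)c1ccccc1` gives 12800 nM in a functional assay on MDA-MB-231 cells (Homo sapiens) for antiproliferative activity, read by MTT assay, with a stated time of 72 h; on this read-out lower numbers stand for stronger inhibition and higher numbers for weaker inhibition. Compound 2 `Cc1ccc(NC(=O)Nc2cccc(-c3nc(-c4ccc(NC(=O)c5cccnc5)cc4Cl)no3)c2)cc1` gives 3500 nM in this assay, a 3.7-fold lower number from compound 1 to compound 2 (0.56 log units; beyond the scatter). Compound 3 `C#Cc1cccc(NC(=O)Nc2cccc(-c3nc(-c4ccc(NC(=O)c5cccnc5)cc4Cl)no3)c2)c1` reaches only > 10000 nM in this assay, which is a limit of the measurement rather than a number. The step of an at least 2.8-fold higher number from compound 2 to compound 3 (0.45 log units; beyond the scatter) is therefore at least modest, while the step that the limit leaves unreadable from compound 1 to compound 3 cannot be read. Compound 4 `CS(=O)(=O)Nc1ccc(NC(=O)Nc2cccc(-c3nc(-c4ccc(NC(=O)c5cccnc5)cc4Cl)no3)c2)cc1` differs from compound 3 by 4-(methanesulfonamido)phenyl in place of 3-ethynylphenyl on an amide-type nitrogen. Within the data shown here, only the step from compound 2 to compound 3 touches this position, and it shows that a change there can move the number beyond the scatter. With so little to go on, compound 4 is expected to give about 8000 nM, within 2500 nM to 30000 nM, an expected step of an at least 1.2-fold lower number from compound 3 to compound 4 (0.09 log units; that floor lies within the scatter), though another limit remains possible.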

Compound 4, half-maximal inhibitory concentration: 600 nM
Beside the measured number, compound 4's estimate is 13-fold (1.12 log units) above it; the whole stated range lies above it.
By their numbers in this assay, from the lowest: compound 4; then compound 2; then compound 1.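

Putting 4-(methanesulfonamido)phenyl on this amide-type nitrogen gives an at least 16-fold lower number from compound 3 to compound 4 (1.22 log units; beyond the scatter), and methanesulfonamido in place of methyl on the aromatic carbon gives a 5.8-fold lower number from compound 2 to compound 4 (0.77 log units; beyond the scatter), so a change at this position can strengthen inhibition as well as weaken it. Replacing phenyl on the carbonyl carbon with (4-(methanesulfonamido)phenyl)amino gives a 21-fold lower number from compound 1 to compound 4 (1.33 log units; beyond the scatter). The step from the ethynyl compound gives only a minimum size, since it starts from a limit: the limit of > 10000 nM in this assay, at which 1 of the 4 values shown sits.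

On these data alone, whether an amine or a carboxylic acid in place of methanesulfonamido would give a similar number remains open. So does the effect of moving methanesulfonamido elsewhere on the ring.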